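The source may hold more compounds than are shown below. What is called first, only, known or untested is meant among the compounds shown, and "the series" means these compounds.

Measured so far in an assay on CHO cells for displacement of a labelled ligand from prostaglandin D2 receptor 2 (Homo sapiens), read by scintillation counting; on this read-out lower numbers stand for stronger inhibition and higher numbers for weaker inhibition:

- compound 1, `CCCS(=O)(=O)c1cc(C#Cc2cc(Cl)ccc2OCC(=O)O)c(C)cc1NC(C)=O`: 1.3 nM
- compound 2, `Cc1ccc(S(=O)(=O)Cc2ccccc2)cc1C#Cc1cc(Cl)ccc1OCC(=O)O`: 5 nM
- compound 3, `CCCS(=O)(=O)c1ccc(C)c(C#Cc2cc(Cl)ccc2OC(CC)C(=O)O)c1`: 30 nM

Compound 2 sits second highest of the three numbers. Compound 1 gives a lower number, beyond the usual scatter; compound 3 gives a higher number, also beyond the scatter. No pair among these three differs in one place only, so none of them shows the effect of a single change on its own.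

Compound 4, `Cc1ccc(S(=O)(=O)N(C)C)cc1C#Cc1cc(Cl)ccc1OCC(=O)O`, is the next one to be run in this assay. Relative to compound 2 it carries dimethylamino in place of benzyl on a sulfonyl sulfur, that is, benzylsulfonyl to dimethylsulfamoyl. Going by the values given here, no measured pair here shows a change of that kind, so the direction of the step is not anchored by data. A modest rise of the number is expected, near the edge of the scatter. The step from compound 2 expected for compound 4 is a 2.0-fold higher number from compound 2 to compound 4 (0.30 log units; within the scatter). For compound 4 the estimate in this assay is 10 nM, with a range of 3 nM to 40 nM.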

Compound 4, inhibition constant: 5 nM
Compound 4: the middle estimate sits 2.0-fold (0.30 log units) above what was measured, within the range that was stated.
By their numbers in this assay, from the lowest: compound 1; then compounds 2 and 4 (each within the scatter of the next); then compound 3.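

In this assay, dimethylamino in place of benzyl on a sulfonyl sulfur gives (no change at the digits printed from compound 2 to compound 4 (within the scatter)). For this pair, the number therefore does not depend on the benzyl group, with its 7 heavy atoms and six-membered aromatic ring: dimethylamino, with 3 heavy atoms and no ring, reads the same within the scatter, and a nitrogen can stand on the sulfonyl sulfur in place of a carbon. No measurement available here explains this result.

Still open, going by these compounds, is how a morpholine ring or a plain amino group on the same sulfonyl sulfur would read on this core. Also open, on these data alone, is whether the same exchange would read alike on the cores of compound 1 and compound 3, which each carry further differences.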